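Sulfonyl-to-amine swap on the benzamide of compound 2

The compounds below may be only part of what the source reports. "The series", "measured", "known", "first", "only" and "open" are said of these compounds alone.

Two compounds of the series have numbers in an assay on THP-1 cells for antagonist activity at P2X purinoceptor 7 (Homo sapiens), read by ELISA, with a stated time of 30 min; on this read-out higher numbers stand for weaker inhibition and lower numbers for stronger inhibition. Compound 1 `O=C(NC1CC1)c1cccc(S(=O)(=O)Oc2ccc(-c3cncn3C3CCN(C(=O)c4ccc(Cl)c(C(F)(F)F)c4)CC3)cc2)c1` carries a cyclopropylamide on its sulfonate aryl and a chloro-trifluoromethyl benzamide; in this assay compound 1 gives 58 nM. Compound 2 `CS(=O)(=O)c1ccc(C(=O)N2CCC(n3cncc3-c3ccc(OS(=O)(=O)c4cccc5cnccc45)cc3)CC2)cc1` instead carries an isoquinoline sulfonate and a methylsulfonyl benzamide; in this assay compound 2 gives 0.32 nM, the lower of the two numbers, and the gap to compound 1 lies well beyond the scatter. The two differ in more than one place, so no single change can be read from that pair.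

Compound 3 `CN(C)c1ccc(C(=O)N2CCC(n3cncc3-c3ccc(OS(=O)(=O)c4cccc5cnccc45)cc3)CC2)cc1` keeps the core of compound 2 and differs in one place: dimethylamino in place of methylsulfonyl on an aromatic carbon, on an aromatic carbon of a six-membered aromatic ring of carbon only, para to a large group. Going by the values given here, no measured pair shows this change, so its size has to be guessed. The expectation is a small to moderate loss, since compound 2 already sits at a very low number and there is no shown step to support a gain. For compound 3 the estimate in this assay is 1.5 nM, within 0.3 nM to 8 nM, which means an expected step of a 4.7-fold higher number from compound 2 to compound 3 (0.67 log units; beyond the scatter).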

Compound 3, half-maximal inhibitory concentration: 2.19 nM
Compound 3: the middle estimate sits 1.5-fold (0.16 log units) below what was measured; low and high end bracket the measured number.
By their numbers in this assay, from the lowest: compound 2; then compound 3; then compound 1.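

Notes on the benzamide substituent: this is the first single-place step in the series. In this assay, dimethylamino in place of methylsulfonyl, on an aromatic carbon para to a large group, gives a 6.8-fold higher number from compound 2 to compound 3 (0.84 log units; beyond the scatter); the step is modest but beyond the scatter, so this place does respond to the substituent. The response is limited, though, as the exchange of a group with 2 hydrogen-bond acceptors and 2 double bonds outside aromatic rings for one with 1 acceptor and no such double bonds still leaves compound 3 at 2.19 nM. Nothing available explains the loss or assigns it to any one of these differences.

Still open, as far as these compounds go, is how other groups at this same carbon would read, for example a primary amine, a carboxylic acid, a nitrile or a methoxy group, and whether any of them would match or go below compound 2. Also open, from the compounds shown here alone, is whether the same swap gives a step of similar size when the isoquinoline sulfonate is replaced by another sulfonate aryl.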